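The compounds below may be only part of what the source reports. "The series", "measured", "known", "first", "only" and "open" are said of these compounds alone.

Measured so far in a functional assay on SW48 cells (Homo sapiens) for antiproliferative activity, read by MTT assay, with a stated time of 72 h; on this read-out lower numbers stand for stronger inhibition and higher numbers for weaker inhibition:
- compound 1 `COc1ccc(C(=O)N[C@@H]2C(=O)N(c3cc(OC)c(OC)c(OC)c3)[C@H]2c2ccc(OC)c(O)c2)cc1`: 108 nM
- compound 2 `COc1ccc([C@H]2[C@H](NC(=O)c3cc(OC)c(OC)c(OC)c3)C(=O)N2c2cc(OC)c(OC)c(OC)c2)cc1O`: 564 nM

Of these two, compound 2 has the higher number, making it the weaker inhibitor. Compound 3 `COc1ccc([C@H]2[C@H](NC(=O)c3ccc4ccccc4c3)C(=O)N2c2cc(OC)c(OC)c(OC)c2)cc1O` is still unmeasured. It has naphthalen-2-yl in place of 3,4,5-trimethoxyphenyl on a carbonyl carbon. Within the data shown here, only one measured step involves this place: a 5.2-fold higher number from compound 1 to compound 2 (0.72 log units; beyond the scatter), when 3,4,5-trimethoxyphenyl replaced 4-methoxyphenyl. Among the measured compounds shown here, removing 3,4,5-trimethoxyphenyl may therefore lower the number in this assay, although no measured compound carries naphthalen-2-yl. A modest fall is expected, with an estimated step of a 2.6-fold lower number from compound 2 to compound 3 (0.41 log units; beyond the scatter). The expected value for compound 3 is 220 nM, with an estimated range of 60 nM to 800 nM.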

Compound 3, half-maximal inhibitory concentration: 220 nM
The estimate for compound 3 equals the measured number at the digits printed; low and high end bracket the measured number.
By their numbers in this assay, from the lowest: compound 1; then compound 3; then compound 2.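

In this assay, naphthalen-2-yl in place of 3,4,5-trimethoxyphenyl on this carbonyl carbon gives a 2.6-fold lower number from compound 2 to compound 3 (0.41 log units; beyond the scatter), so this position can hold a group of carbon-only aromatic rings without any methoxy group and still improve on compound 2. The 4-methoxyphenyl group nevertheless remains ahead of naphthalen-2-yl, with a 2.0-fold higher number from compound 1 to compound 3 (0.31 log units; beyond the scatter). No measurement available here explains this order of the three groups.

On these data alone, it remains open how a plain phenyl, or a ring carrying an amine or a carboxylic acid, would fare on this carbonyl carbon. Whether the same order holds in other cell lines is also unknown.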